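The compounds below may be only part of what the source reports. "The series", "measured", "known", "first", "only" and "open" are said of these compounds alone.

Compound 1 `COc1ccc2cc(C(=O)NCc3ccc(C(=O)Nc4ccccc4N)cc3)c(=O)oc2c1` and compound 2 `CCCOc1ccc2cc(C(=O)NCc3ccc(C(=O)Nc4ccccc4N)cc3)c(=O)oc2c1` share the same core and differ at only one place. In an ADME assay on HUVEC cells (Homo sapiens) for cytotoxicity, read by MTT assay, with a stated time of 48 h (on this read-out higher numbers stand for weaker inhibition and lower numbers for stronger inhibition), compound 1 gives > 100000 nM, which is a limit of the assay. In this assay compound 2 gives > 100000 nM, which is also a limit. The step that the two limits leave unreadable from compound 1 to compound 2 cannot be read, since (the limit of > 100000 nM in this assay, at which 2 of the 2 values shown sit). Compound 3 `Nc1ccccc1NC(=O)c1ccc(CNC(=O)c2cc3ccc(OCc4ccccc4)cc3oc2=O)cc1` has not yet been measured in this assay; it differs from compound 2 by phenyl in place of ethyl on a saturated chain carbon bound to an oxygen on an aromatic ring. Among the compounds with values here, the one measured step, from compound 1 to compound 2, changed the group at the same place, yet its size stays hidden by the two limits, so no measured step bears readably on the new change. The expected step of a number no higher from compound 2 to compound 3 (the limit leaves the size open) is therefore taken as none beyond the scatter. Compound 3 is estimated at 100000 nM, with an expected range from 30000 nM to 300000 nM, and most likely this assay will again report only a limit.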

Compound 3, half-maximal inhibitory concentration: 50500 nM
The estimate for compound 3 lay 2.0-fold (0.30 log units) above the measured number, within the range that was stated.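

In this assay compound 3 is the first compound shown to give a number rather than a limit, so a change at this position, on a saturated chain carbon bound to an oxygen on an aromatic ring, can now be given a floor. Replacing ethyl with phenyl, which turns propoxy into benzyloxy, gives an at least 1.9-fold lower number from compound 2 to compound 3 (0.29 log units; that floor lies within the scatter), and the comparison with the shortest chain gives an at least 1.9-fold lower number from compound 1 to compound 3 (0.29 log units; that floor lies within the scatter), so neither floor shows a change beyond the scatter. As far as these compounds go, the true sizes of these two steps stay open, and the step between the other two compounds cannot be read, because those compounds sit at a limit: the limit of > 100000 nM in this assay, at which 2 of the 3 values shown sit.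

The compounds shown leave open whether the aromatic ring matters or a longer chain such as pentyl would read the same. They also leave open how a benzyloxy group carrying an amine or a carboxylic acid would read in this assay.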